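Ring size at the chain end: from pyrrolidine to methylpiperidine

The compounds below may be only part of what the source reports. "The series", "measured", "known", "first", "only" and "open" are said of these compounds alone.

Three compounds share one core and differ only in the saturated ring at the end of the chain. Compound 1 `COc1cc2c(Nc3nc4ccc(C(=O)Nc5c(C)cccc5Cl)cc4s3)ncnc2cc1OCCCN1CCC(C)CC1` gives 8300 nM in a functional assay on K562 cells (Homo sapiens) for cytotoxicity, read by WST assay, with a stated time of 72 h; on this read-out lower numbers stand for stronger inhibition and higher numbers for weaker inhibition. Compound 2 `COc1cc2c(Nc3nc4ccc(C(=O)Nc5c(C)cc(C)cc5C)cc4s3)ncnc2cc1OCCCN1CCCCC1` gives 9300 nM, and compound 3 `COc1cc2c(Nc3nc4ccc(C(=O)Nc5c(C)cc(C)cc5C)cc4s3)ncnc2cc1OCCCN1CCCC1` gives 4300 nM. Among these, compound 3 is separated from compound 2 by a 2.2-fold lower number from compound 2 to compound 3 (0.34 log units; beyond the scatter), while its gap to compound 1 stays within the scatter, so no ordering between compound 3 and compound 1 can be claimed.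

Compound 4 `COc1cc2c(Nc3nc4ccc(C(=O)Nc5c(C)cc(C)cc5C)cc4s3)ncnc2cc1OCCCN1CCCCC1C` is not yet measured. It differs from compound 3 by 2-methylpiperidin-1-yl in place of pyrrolidin-1-yl on a saturated chain carbon, three bonds along the chain from an oxygen on an aromatic ring. Within the data shown here, the one measured step that bears on this is a 2.2-fold lower number from compound 2 to compound 3 (0.34 log units; beyond the scatter), where the six-membered ring gave way to the five-membered one and the number fell. Compound 4 restores a six-membered ring, now carrying a methyl, so the step is expected to run the other way and a number near that of compound 2 is expected. For compound 4 the expected change is a 1.9-fold higher number from compound 3 to compound 4 (0.27 log units; within the scatter). Compound 4 is therefore estimated at 8000 nM, within a range from 3500 nM to 18000 nM.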

Compound 4, half-maximal inhibitory concentration: 3500 nM
Estimate against measurement, compound 4: 2.3-fold (0.36 log units) above; low and high end bracket the measured number.
By their numbers in this assay, from the lowest: compounds 4, 3, 1 and 2 (each within the scatter of the next, the first and the last beyond it).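

In this assay, 2-methylpiperidin-1-yl in place of pyrrolidin-1-yl gives a 1.2-fold lower number from compound 3 to compound 4 (0.09 log units; within the scatter), so these two chain ends cannot be told apart, even though one is a six-membered ring and the other a five-membered ring. Methyl in place of hydrogen on a saturated ring carbon gives a 2.7-fold lower number from compound 2 to compound 4 (0.42 log units; beyond the scatter), which shows that ring size alone does not set the number at this position: one added methyl on the six-membered ring is enough to shift it. Nothing available explains why this methyl has this effect.

Still open is whether the methyl's place on the ring matters, since 3-methylpiperidin-1-yl is absent from the compounds shown. Also open, from the compounds shown here alone, is how 2-methylpyrrolidin-1-yl or a morpholine ring would behave at the end of this chain.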